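A few compounds are considered here, and "the series" means these few. Any claim that something is new, unique, unknown or untested is made for them only; others in the source may bear on it.

Measured so far:
Compound 1 `CO/N=C1/C=C(C#Cc2ccncc2)CCC1` gives 54.8 nM in an assay on brain (strain Sprague-Dawley) for displacement of a labelled ligand from metabotropic glutamate receptor 5 (Rattus norvegicus), with a stated time of 45 min; a lower number here means a stronger inhibitor, a higher number a weaker inhibitor.
Compound 2 `Fc1cccc(O/N=C2/C=C(C#Cc3ccccn3)CCC2)n1` gives 9.15 nM in this assay.

Of these two numbers, compound 2 has the lower one, so it is the stronger inhibitor of the pair; compound 1 stands at a higher number, and the gap between them is wider than the usual scatter of this kind of measurement. The two compounds differ in more than one place at once, so nothing can be said about what any single change contributes.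

Compound 3 `CO/N=C1/C=C(C#Cc2ccccn2)CCC1` has not yet been measured. It is reached from compound 2 by a single change: methyl in place of 6-fluoropyridin-2-yl on an oxygen. Going by the values given here, no comparable single step between measured compounds is available, so the size of the effect has to be guessed. The expectation is that compound 3 is somewhat weaker than compound 2, with the estimated step from compound 2 to compound 3 being a 2.7-fold higher number from compound 2 to compound 3 (0.44 log units; beyond the scatter), a modest rise that may only just clear the scatter. Compound 3 is therefore expected to show about 25 nM in this assay, in a range from 8 nM to 80 nM.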

Compound 3, inhibition constant: 2.2 nM
Compound 3: the middle estimate sits 11-fold (1.06 log units) above what was measured, and the stated range ends above it.
By their numbers in this assay, from the lowest: compound 3; then compound 2; then compound 1.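

Replacing the 6-fluoropyridin-2-yl on the oxygen with methyl gives a 4.2-fold lower number from compound 2 to compound 3 (0.62 log units; beyond the scatter) in this assay, a change that lies beyond the usual scatter and moves toward a stronger inhibitor. This shows that an aromatic ring of 7 heavy atoms on this oxygen is not needed for strong inhibition here, since a single methyl carbon does better in this pair. Nothing among the available data explains why the smaller group gives the lower number, so this single step records the size of the effect but not its cause.

Going by these compounds alone, only two groups on this oxygen can be compared directly. The step shows no trend with size, and an ethyl group or a longer chain such as n-propyl could fall anywhere relative to methyl. As far as these compounds go, it also remains open whether the ring or its fluorine matters more in the higher number of compound 2, a question that a plain phenyl or unsubstituted pyridin-2-yl on the same oxygen could help to separate.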